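The source may hold more compounds than are shown below. What is called first, only, known or untested is meant among the compounds shown, and "the series" means these compounds.

Of the compounds shown here, three built on a shared core have been measured in a functional assay on MGC-803 cells (Homo sapiens) for antiproliferative activity, read by CellTiter-Glo, with a stated time of 72 h; a higher number here means a weaker inhibitor, a lower number a stronger inhibitor. Compound 1 (`O=C(NO)c1ccc(/C=C/c2ccnc(-c3cc(F)ccc3O)c2)cc1`) gives 1920 nM, compound 2 (`O=C(NO)c1ccc(/C=C/c2ccnc(-c3cccc(O)c3)c2)cc1`) gives 2100 nM, and compound 3 (`Cc1ccc(-c2cc(/C=C/c3ccc(C(=O)NO)cc3)ccn2)c(F)c1`) gives 770 nM. The last is the lowest number of the three, and both steps towards it lie beyond the scatter: a 2.5-fold lower number from compound 1 to compound 3 (0.40 log units; beyond the scatter), and a 2.7-fold lower number from compound 2 to compound 3 (0.44 log units; beyond the scatter). The other two values stand apart by only a 1.1-fold higher number from compound 1 to compound 2 (0.04 log units; within the scatter).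

The next compound to be measured is compound 4 (`O=C(NO)c1ccc(/C=C/c2ccnc(-c3ccsc3)c2)cc1`). Thiophen-3-yl stands in place of 2-fluoro-4-methylphenyl on an aromatic carbon, next to the ring nitrogen: thiophen-3-yl in place of 2-fluoro-4-methylphenyl on an aromatic carbon. For the measured compounds named here, no measured compound carries thiophen-3-yl, so no step speaks for this group directly. The nearest guides are the two modest steps into compound 3, read in reverse. Among the three measured compounds, those without 2-fluoro-4-methylphenyl have the higher numbers, with compound 1 at 1920 nM and compound 2 at 2100 nM. A small move towards a higher number, no larger than those two steps, is therefore expected. The estimate is a 1.6-fold higher number from compound 3 to compound 4 (0.21 log units; within the scatter). Compound 4 is expected at 1250 nM, with an estimated range of 480 nM to 3200 nM.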

Compound 4, half-maximal inhibitory concentration: 3680 nM
Estimate against measurement, compound 4: 2.9-fold (0.47 log units) below; the whole stated range lies below it.
By their numbers in this assay, from the lowest: compound 3; then compounds 1, 2 and 4 (each within the scatter of the next).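

In this assay, replacing the six-membered carbon ring of compound 3 with thiophen-3-yl, a five-membered aromatic ring with 1 hetero atom, on the aromatic carbon next to the ring nitrogen gives the largest step shown at this position (a 4.8-fold higher number from compound 3 to compound 4 (0.68 log units; beyond the scatter)), so this place does respond to the change of group. The earlier compounds shown here left room for a simple reading in which the hydroxyl marked the higher numbers, but compound 4 carries no hydroxyl and still does not separate from the two hydroxyphenyl compounds (a 1.8-fold higher number from compound 2 to compound 4 (0.24 log units; within the scatter); a 1.9-fold higher number from compound 1 to compound 4 (0.28 log units; within the scatter)), so it goes against that reading and leaves compound 3 alone at the low end. No measurement beyond these antiproliferative values bears on the result.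

The compounds shown do not tell whether the fluorine, the methyl or the six-membered ring itself sets compound 3 apart, a question that plain phenyl, 2-fluorophenyl and 4-methylphenyl would divide. They also leave open whether thiophen-3-yl speaks for five-membered rings in general, or whether furan-3-yl or a thiophen-3-yl carrying a methyl would fall elsewhere.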